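This account rests on a few compounds, and the source may have more. Where it says the series, first, only, none or still open, it means among the compounds named here.

Among the measured compounds shown here, compound 1 `Oc1ccc(-c2cc(-c3ccsc3)nc(-c3cccc(Cl)c3)c2)cc1` was tested in a functional assay on HCT-15 cells (Homo sapiens) for cytotoxicity, read by CCK-8 assay and cell counting, with a stated time of 2 days (on this read-out lower numbers stand for stronger inhibition and higher numbers for weaker inhibition), and gives 5760 nM, the lowest of the three numbers measured so far. Compound 2 `Oc1ccc(-c2cc(-c3cccc(Cl)c3)nc(-c3ccco3)c2)cc1` gives 8020 nM in this assay, and compound 3 `Oc1ccc(-c2cc(-c3cccnc3)nc(-c3cccc(Cl)c3)c2)cc1` gives 21300 nM. The step of a 1.4-fold higher number from compound 1 to compound 2 (0.14 log units; within the scatter) lies within the scatter of this assay, whereas a 3.7-fold higher number from compound 1 to compound 3 (0.57 log units; beyond the scatter) and a 2.7-fold higher number from compound 2 to compound 3 (0.42 log units; beyond the scatter) are modest steps beyond it. All three of these steps exchange the thiophen-3-yl, furan-2-yl or pyridin-3-yl group on the shared core, and none of them touches the 3-chlorophenyl group.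

Compound 4 `Oc1ccc(-c2cc(-c3ccsc3)nc(-c3ccccc3Cl)c2)cc1` has not yet been measured in this assay. It differs from compound 1 in one place only: 2-chlorophenyl in place of 3-chlorophenyl on an aromatic carbon. For the measured compounds named here, no measured step exchanges 3-chlorophenyl for 2-chlorophenyl, so the numbers at hand say nothing direct about this change, and there is no ground to expect a step beyond the scatter in either direction. The estimate therefore stays close to compound 1, with a wide range to allow for the lack of a comparable step. Compound 4 is expected to give about 7000 nM, somewhere between 2500 nM and 20000 nM. This estimate means an expected step of a 1.2-fold higher number from compound 1 to compound 4 (0.08 log units; within the scatter).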

Compound 4, half-maximal inhibitory concentration: 5830 nM
Compound 4: middle estimate off by 1.2-fold (0.08 log units), on the high side, within the range that was stated.
By their numbers in this assay, from the lowest: compounds 1, 4 and 2 (each within the scatter of the next); then compound 3.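

Exchanging 3-chlorophenyl for 2-chlorophenyl is the first change shown at this position, on the ring carbon next to the ring nitrogen, as the earlier steps all exchanged the group on the other side of the shared core. In this assay, this exchange gives a 1.0-fold higher number from compound 1 to compound 4 (0.01 log units; within the scatter), so with thiophen-3-yl in place, the read-out does not separate these two placements of the chlorine on the phenyl group. No measured information at hand bears on why the two compounds read alike, so this result records a lack of difference without giving any cause for it.

The compounds shown leave open whether the same holds when furan-2-yl or pyridin-3-yl replaces thiophen-3-yl, since this one pair is the only comparison of the two chlorine placements. They also leave open what happens with 4-chlorophenyl, with a phenyl group carrying no chlorine at all, or with an amine or a carboxylic acid in place of the chlorine, so the tolerance seen here cannot be extended to other groups at this position.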